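Removing the ring methyl from compound 3

A few compounds are considered here, and "the series" means these few. Any claim that something is new, unique, unknown or untested is made for them only; others in the source may bear on it.

In an ADME assay on the whole organism (Mus musculus, strain C57BL6/N) for metabolic stability, read by LC-MS, with a stated time of 24 h, at a dose of 50 mg/kg by the oral route (a lower number here means that the compound disappears faster, a higher number that the compound lasts longer), compound 1 `CNc1cc(C)c(C(N)=O)cn1` gives 1.79 h as its half-life, compound 2 `NC(=O)c1cnc2c(c1Cl)CCN2` gives 2.87 h and compound 3 `C[C@@H]1Cc2cc(C(N)=O)cnc2N1` gives 2.89 h on the same read-out. Compound 3 therefore lies within the scatter of both other compounds, and the three numbers do not separate. Compound 4 `NC(=O)c1cnc2c(c1)CCN2` differs from compound 3 by one change hydrogen in place of methyl on a saturated ring carbon with hydrogen in place of methyl on a saturated ring carbon. Among the measured compounds shown here, no measured pair isolates this change, so direct evidence for its size is lacking. The expected step of a 1.1-fold lower number from compound 3 to compound 4 (0.05 log units; within the scatter) in this assay is small, with no shift beyond the scatter in either direction. That expectation rests on compound 1 at 1.79 h and compound 3 at 2.89 h as values that stay within the scatter of each other despite their different structures. Compound 4 is estimated at 2.6 h with an expected range of 1.5 h to 4.3 h as its half-life.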

Compound 4, half-life: 1.46 h
Estimate against measurement, compound 4: 1.8-fold (0.25 log units) above, and the stated range ends above it.
By their numbers in this assay, from the lowest: compounds 4, 1, 2 and 3 (each within the scatter of the next).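

In this assay hydrogen in place of methyl on a saturated ring carbon, next to the ring nitrogen, now has a direct measure: a 2.0-fold lower number from compound 3 to compound 4 (0.30 log units; within the scatter) is the size of this change, so the methyl is not shown to alter half-life at this position. Hydrogen in place of chloro on an aromatic carbon gives a 2.0-fold lower number from compound 2 to compound 4 (0.29 log units; within the scatter) in the same assay, so neither change separates from the scatter. Nothing measured on this series accounts for the size of either step.

On these data alone, it remains open whether an ethyl, a hydroxyl or a fluorine on the saturated ring carbon would give a half-life that separates from that of compound 4. Equally open, as far as these compounds go, is whether a nitrile or a methoxy group on the aromatic carbon would do so.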